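Formalin paw edema: single-bromo variant of compound 3

This account rests on a few compounds, and the source may have more. Where it says the series, first, only, none or still open, it means among the compounds named here.

Measured so far:
Compound 1, `O=c1cc(CNc2nc(-c3cc4cc(Br)cc(Br)c4oc3=O)cs2)c2cc(Cl)ccc2[nH]1`, 2.85%
Compound 2, `Cc1cccc2c(CNc3nc(-c4cc5cc(Br)ccc5oc4=O)cs3)cc(=O)[nH]c12`, 1.6%
Compound 3, `O=c1cc(CNc2nc(-c3cc4cc(Br)cc(Br)c4oc3=O)cs2)c2ccc(Cl)cc2[nH]1`, 2.89%

All three measured compounds were run in a functional assay on the whole organism for inhibition, with Rattus norvegicus as the target, read by paw edema, in the formalin test, at a dose of 100 mg/kg by the intraperitoneal route; a lower number here means less inhibition, a higher number more inhibition at the dose given (going by the name of the read-out). In this assay compound 1 gives 2.85%, compound 2 gives 1.6% and compound 3 gives 2.89%. The three numbers sit close to the floor of the read-out, and the gaps between them are all within the usual scatter: compound 3 is separated from compound 1 by essentially nothing and from compound 2 by a gap that also lies within the scatter. On these numbers the inhibition in this assay is level across the three compounds.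

The next compound, compound 4, `O=c1cc(CNc2nc(-c3cc4cc(Br)ccc4oc3=O)cs2)c2ccc(Cl)cc2[nH]1`, is to be measured in this assay. It differs from compound 3 in one place: hydrogen in place of bromo on an aromatic carbon. The two bromo groups of compound 3 are reduced to one, so compound 4 carries a single bromo group on that ring, as compound 2 does on its ring.

Nothing measured here points to a step beyond the scatter. Compound 2, with one bromo group, gives 1.6%, and compound 3 with two gives 2.89%, both low. For compound 4 the estimated value is 2.5%, with a range of 0% to 12%. The expected step of a number 0.4 percentage points lower from compound 3 to compound 4 (within the scatter) is small, within the scatter and of no clear direction.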

Compound 4, a percentage reported as inhibition, in the whole organism at one dose (the size of the read-out at that dose, not a potency): 2.4%
Compound 4: middle estimate off by 0.1 percentage points, on the high side; the measured number falls inside the stated range.
By their numbers in this assay, from the lowest: compounds 2, 4, 1 and 3 (each within the scatter of the next).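

Among the compounds shown here, compound 3 and compound 4 are the only pair here that differ in one place, so the bromo group can now be read on its own, which the earlier compounds did not allow. In this assay, hydrogen in place of bromo on an aromatic carbon, ortho to a fused ring and meta to the remaining bromo group, gives a number 0.5 percentage points lower from compound 3 to compound 4 (within the scatter), so at this position the change from bromo to hydrogen leaves the read-out level and close to its floor. No measurement available here speaks to the reason for this result.

With both compounds of the pair this close to the floor of the read-out, the step says little about how this position would behave in a compound with a clearly higher number. On these data alone, whether an amine, a carboxylic acid or a methoxy group on this aromatic carbon would move the number in this assay beyond the scatter remains open, as does whether the remaining bromo group can be replaced in the same way.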